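A Bromine Added on the Phenyl Ring of Compound 2

The source may report more compounds than this note shows. Statements on the series, on what has been measured and on what is new or still open speak of the compounds shown alone.

Compound 1: `CCC(=O)Nc1c(C(O)(C(F)(F)F)C(F)(F)F)ccc2ccccc12`, 15 nM
Compound 2: `O=C(Nc1c(C(O)(C(F)(F)F)C(F)(F)F)ccc2ccccc12)c1ccccc1`, 44 nM

In an assay on LtK cells with ATP-sensitive inward rectifier potassium channel 11 (Homo sapiens) as the target (a higher number here means that more compound is needed for the effect, a lower number that less compound is needed), compound 2 gives 44 nM, the highest of the two numbers. Compound 1 gives 15 nM. For the measured compounds named here, the one measured step, a 2.9-fold higher number from compound 1 to compound 2 (0.47 log units; beyond the scatter), concerns the group on the carbonyl carbon and not a substituent on the phenyl ring. Compound 3 `O=C(Nc1c(C(O)(C(F)(F)F)C(F)(F)F)ccc2ccccc12)c1cccc(Br)c1` differs from compound 2 by bromo in place of hydrogen on an aromatic carbon. Going by the values given here, no measured step bears on this change, so the expected step in this assay is a 1.1-fold lower number from compound 2 to compound 3 (0.04 log units; within the scatter), within the scatter. Compound 3 is estimated at 40 nM, with a range from 10 nM to 160 nM.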

Compound 3, half-maximal effective concentration: 80 nM
For compound 3 the middle estimate is 2.0-fold (0.30 log units) below the measured one; measured number inside the range.
By their numbers in this assay, from the lowest: compound 1; then compounds 2 and 3 (each within the scatter of the next).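

In this assay, bromo in place of hydrogen on this aromatic carbon, meta to a large group, gives a 1.8-fold higher number from compound 2 to compound 3 (0.26 log units; within the scatter), so this single change cannot be told apart from the scatter. Replacing ethyl on the carbonyl carbon with 3-bromophenyl gives a step beyond the scatter, a 5.3-fold higher number from compound 1 to compound 3 (0.73 log units; beyond the scatter). No available evidence bears on the reason for either step. Open, going by these compounds, is whether bromo would read the same elsewhere on the phenyl ring, and whether a methoxy group, an amine or a carboxylic acid in its place would shift the number.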